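This account rests on a few compounds, and the source may have more. Where it says the series, first, only, none or still open, it means among the compounds named here.

Compound 1 `CSc1cc(C)nc(NC(=S)NC(=O)c2c(-c3ccc(Cl)cc3Cl)noc2C)n1`, compound 2 `Cc1cc(Cl)nc(NC(=S)NC(=O)c2c(-c3ccc(Cl)cc3Cl)noc2C)n1` and compound 3 `COc1cc(Cl)nc2n/c(=N/C(=O)c3c(-c4ccc(Cl)cc4Cl)noc3C)sn12` were measured in a functional assay on the whole organism (strain L.) for inhibition, with Echinochloa crus-galli as the target, with a stated time of 72 h, tested at 10 mg/L; on this read-out lower numbers stand for less inhibition of growth and higher numbers for more inhibition of growth at the one concentration tested. In this assay compound 1 gives 27.4%, compound 2 gives -6.84% and compound 3 gives 10.8%. Between compound 2 and compound 1 one structural change was made, (methylsulfanyl in place of chloro on an aromatic carbon), and it made a large step: a number 34.2 percentage points higher from compound 2 to compound 1 (beyond the scatter). Compound 3 stands between the two, and the difference between its core and the core of compound 2 is not broken down here.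

Compound 4 `COc1cc(SC)nc2n/c(=N/C(=O)c3c(-c4ccc(Cl)cc4Cl)noc3C)sn12` has not yet been measured. Among the compounds with values here, it carries the same kind of change as the one from compound 2 to compound 1, but made on compound 3: methylsulfanyl in place of chloro on an aromatic carbon. The surroundings are not the same word for word: on compound 3 the place is meta to a fused ring, para to a fused ring and meta to a methoxy group, whereas on compound 2 it is meta to a large group and meta to a methyl group. For that reason the account does not assume the step will be repeated in full.

Because compound 1 sits at 27.4% after the earlier change, a rise from compound 3 is expected, but a smaller one: the estimate for the step is a number 19.2 percentage points higher from compound 3 to compound 4 (beyond the scatter), made on a different core. Compound 4 is therefore expected to give about 30% in this assay, with a plausible range from 10% to 52%.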

Compound 4, percent growth inhibition at one concentration: 21.4%
The estimate for compound 4 lay 8.6 percentage points above the measured number; the measured number falls inside the stated range.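

In this assay, methylsulfanyl in place of chloro on an aromatic carbon again goes with a rise on the second core, a number 10.6 percentage points higher from compound 3 to compound 4 (beyond the scatter), so within these two pairs the direction of the step carries over from one core to the other. The size of the step does not carry over, and the two steps differ by more than the scatter allows: the same change on two cores in this assay, a number 34.2 percentage points higher (beyond the scatter) from compound 2 to compound 1 and a number 10.6 percentage points higher (beyond the scatter) from compound 3 to compound 4, 23.6 percentage points apart, beyond the scatter of two such steps. This shows that the gain seen on one core cannot be transferred at full size to the other, but two pairs cannot show why the sizes differ, whether the core itself or the different surroundings of the changed carbon account for the gap, or whether the direction would hold on a third core.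

The compounds shown leave open how other groups on this aromatic carbon would compare with chloro and methylsulfanyl on either core, for example an amine or a longer chain attached through sulfur. They also leave open whether the order among these compounds would stay the same at other concentrations, since the read-out here comes from one concentration only.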